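A few compounds are considered here, and "the series" means these few. Any claim that something is new, unique, unknown or untested is made for them only; others in the source may bear on it.

In an assay on isolated protein for inhibition of glutathione S-transferase P (Homo sapiens), with a stated time of 10 min (on this read-out higher numbers stand for weaker inhibition and lower numbers for stronger inhibition), the three measured compounds gave these numbers:

Compound 1 `O=C(CCC(=O)OCCCCCCSc1ccc([N+](=O)[O-])c2nonc12)Nc1ccccc1Cl`: 15500 nM
Compound 2 `Cc1ccc(NC(=O)CCC(=O)OCCCCCCSc2ccc([N+](=O)[O-])c3nonc23)cc1`: 6800 nM
Compound 3 `CN(C)CCCNC(=O)CCC(=O)OCCCCCCSc1ccc([N+](=O)[O-])c2nonc12`: 160 nM

Compound 1 stands at the highest number of the three, so it is the weakest inhibitor among them. Compound 4 `CCN(CC)CCCNC(=O)CCC(=O)OCCCCCCSc1ccc([N+](=O)[O-])c2nonc12` differs from compound 1 by 3-(diethylamino)propyl in place of 2-chlorophenyl on an amide-type nitrogen. The step that bears most closely on this change is a 97-fold lower number from compound 1 to compound 3 (1.99 log units; beyond the scatter), where the related 3-(dimethylamino)propyl took the same place. The smaller move a 2.3-fold lower number from compound 1 to compound 2 (0.36 log units; beyond the scatter) and the larger move a 43-fold lower number from compound 2 to compound 3 (1.63 log units; beyond the scatter) point the same way. A large drop in the number is therefore expected for compound 4, estimated as a 78-fold lower number from compound 1 to compound 4 (1.89 log units; beyond the scatter). Compound 4 is expected to give about 200 nM, within a range from 60 nM to 650 nM.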

Compound 4, half-maximal inhibitory concentration: 9550 nM
Beside the measured number, compound 4's estimate is 48-fold (1.68 log units) below it; the whole stated range lies below it.
By their numbers in this assay, from the lowest: compound 3; then compounds 2, 4 and 1 (each within the scatter of the next, the first and the last beyond it).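

Exchanging dimethylamino for diethylamino at the end of the chain gives a 60-fold higher number from compound 3 to compound 4 (1.78 log units; beyond the scatter), so a 3-aminopropyl chain on the amide-type nitrogen does not by itself bring a low number; the groups on its terminal nitrogen matter greatly. With diethylamino, the chain stands level with both aromatic groups: a 1.6-fold lower number from compound 1 to compound 4 (0.21 log units; within the scatter), and a 1.4-fold higher number from compound 2 to compound 4 (0.15 log units; within the scatter). Nothing available explains this sharp difference.

Still open, from the compounds shown here alone, is how this place would respond to a pyrrolidine ring or a plain amine at the chain end. A longer chain carrying dimethylamino is also untested among the compounds shown.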